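Working notes: methyl for bromo, compound 2 to compound 4

The source may hold more compounds than are shown below. What is called first, only, known or untested is meant among the compounds shown, and "the series" means these compounds.

Within the data shown here, compound 2 `CCOC(=O)c1cc([Se]c2ccccc2)c2cc(Br)ccc2n1` gives 20800 nM in a functional assay on Jurkat cells (Homo sapiens) for cytotoxicity, read by MTT assay, with a stated time of 24 h (a lower number here means that less compound is needed, a higher number that more compound is needed for the effect), the lowest of the three numbers measured so far. Compound 3 `CCOC(=O)c1cc([Se]Cc2ccccc2)c2cc(Br)ccc2n1` gives 53600 nM in this assay, a change of a 2.6-fold higher number from compound 2 to compound 3 (0.41 log units; beyond the scatter). Compound 1 `CCOC(=O)c1cc([Te]c2ccccc2)c2cc(OC)ccc2n1` gives 77400 nM in this assay; it differs from compound 2 in more than one place, so no single step can be read from that pair. Compound 4 `CCOC(=O)c1cc([Se]c2ccccc2)c2cc(C)ccc2n1` has not been measured. The change from compound 2 to compound 4: methyl in place of bromo on an aromatic carbon. Among the measured compounds shown here, the only measured single step, from compound 2 to compound 3, concerns the group on the selenium and not the bromo, so it gives no direct guidance on methyl in place of bromo. With nothing in the series bearing on this change, the expectation for compound 4 in this assay is a number near that of compound 2, any shift likely within the scatter or at most modest. Compound 4 is therefore estimated at 30000 nM, with a range of 10000 nM to 90000 nM. The expected step is a 1.4-fold higher number from compound 2 to compound 4 (0.16 log units; within the scatter).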

Compound 4, half-maximal effective concentration: 15300 nM
The estimate for compound 4 lay 2.0-fold (0.29 log units) above the measured number; the measured number falls inside the stated range.
By their numbers in this assay, from the lowest: compounds 4 and 2 (each within the scatter of the next); then compounds 3 and 1 (each within the scatter of the next).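

Methyl in place of bromo on an aromatic carbon gives a 1.4-fold lower number from compound 2 to compound 4 (0.13 log units; within the scatter) in this assay, the first reading at this position on the shared core. Among these compounds, in this pair, the exchange leaves no change that can be told from the scatter, whereas the only earlier single step, on the selenium, gave a 2.6-fold higher number from compound 2 to compound 3 (0.41 log units; beyond the scatter). Nothing measured here bears on why the two groups read alike.

From the compounds shown here alone, how an amine, a carboxylic acid or a longer chain on this aromatic carbon would read in this assay remains open. Also open, going by these compounds, is whether methyl for bromo reads the same with benzyl on the selenium, as in compound 3, and the methoxy of compound 1 cannot be separated from its tellurium.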